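Compound 3 to compound 4: from carbamoyl back to methyl ester

This account rests on a few compounds, and the source may have more. Where it says the series, first, only, none or still open, it means among the compounds named here.

Values in a functional assay on HEL cells (Homo sapiens) (a higher number here means that more compound is tolerated, a lower number that less compound is tolerated), for the compounds measured so far:
- Compound 1 `CC(=O)NC1=CS(=O)(=O)O[C@@]12[C@@H](CO[Si](C)(C)C(C)(C)C)O[C@@H](n1cc(C)c(=O)n(C)c1=O)[C@@H]2O[Si](C)(C)C(C)(C)C` gives > 200000 nM (a limit)
- Compound 2 `COC(=O)C(=O)CNC1=CS(=O)(=O)O[C@@]12[C@@H](CO[Si](C)(C)C(C)(C)C)O[C@@H](n1cc(C)c(=O)n(C)c1=O)[C@@H]2O[Si](C)(C)C(C)(C)C` gives > 200000 nM (a limit)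
- Compound 3 `Cc1cn([C@@H]2O[C@H](CO[Si](C)(C)C(C)(C)C)[C@@]3(OS(=O)(=O)C=C3NCC(=O)C(N)=O)[C@H]2O[Si](C)(C)C(C)(C)C)c(=O)n(C)c1=O` gives 14500 nM (a true number)

In this assay, within the data shown here, compound 3 gives 14500 nM as the only true number of the three. The others stand at the limit of > 200000 nM in this assay, at which 2 of the 3 values shown sit, and show no more than that.

Compound 4 `COC(=O)CCNC1=CS(=O)(=O)O[C@@]12[C@@H](CO[Si](C)(C)C(C)(C)C)O[C@@H](n1cc(C)c(=O)n(C)c1=O)[C@@H]2O[Si](C)(C)C(C)(C)C` comes from compound 3 by one change, (methoxycarbonyl)methyl in place of carbamoylcarbonyl on a saturated chain carbon bound to an amine nitrogen (that is, (methoxycarbonyl)methyl in place of carbamoylcarbonyl on a saturated chain carbon bound to an amine nitrogen). The chain now ends in methoxycarbonyl, as in compound 2, and no longer in carbamoyl.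

The closest measured step is an at least 13-fold lower number from compound 2 to compound 3 (1.13 log units; beyond the scatter) with amino in place of methoxy on a carbonyl carbon. It is large and beyond the scatter. The other large one is an at least 13-fold lower number from compound 1 to compound 3 (1.13 log units; beyond the scatter) with (carbamoylcarbonyl)methyl in place of acetyl.

Compound 4 gives up the carbamoyl end, so a large move to a higher number is expected, reversing an at least 13-fold lower number from compound 2 to compound 3 (1.13 log units; beyond the scatter) in direction. Among the measured compounds shown here, no measured compound carries the 2-(methoxycarbonyl)ethyl chain, so the size stays uncertain. The expected step is an 8.3-fold higher number from compound 3 to compound 4 (0.92 log units; beyond the scatter) and the assay may report only a limit. For compound 4 the estimate is 120000 nM with an expected range of 30000 nM to 300000 nM in all.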

Compound 4, half-maximal cytotoxic concentration: 94000 nM
For compound 4 the middle estimate is 1.3-fold (0.11 log units) above the measured one, within the range that was stated.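

Replacing carbamoylcarbonyl with (methoxycarbonyl)methyl on a saturated chain carbon bound to an amine nitrogen gives a 6.5-fold higher number from compound 3 to compound 4 (0.81 log units; beyond the scatter) in this assay, so compound 3 keeps the lowest number of the four. A methoxycarbonyl end does not by itself hold a compound at the limit of the assay: (methoxycarbonyl)methyl in place of (methoxycarbonyl)carbonyl gives an at least 2.1-fold lower number from compound 2 to compound 4 (0.32 log units; beyond the scatter), and 2-(methoxycarbonyl)ethyl in place of acetyl gives an at least 2.1-fold lower number from compound 1 to compound 4 (0.32 log units; beyond the scatter). Both of these steps are one-sided, and their full size stays unknown, as compounds 1 and 2 are known only as limits: the limit of > 200000 nM in this assay, at which 2 of the 4 values shown sit.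

The compounds shown do not separate the part played by the carbamoyl end from that of the carbonyl further along the chain in compound 3, and a 2-carbamoylethyl chain would be the direct comparison. They also leave open how a carboxylic acid at the end of the chain, or a longer chain carrying the methoxycarbonyl end, would stand in this assay.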